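The compounds below may be only part of what the source reports. "The series", "measured", "known", "first", "only" and "open" are said of these compounds alone.

Measured so far:
Compound 1 `CN1CCCN(CCn2ccc3cccc(Br)c32)CC1` — 18%
Compound 2 `CN1CCCN(CCn2ccc3ccc(N)cc32)CC1` — 0%

In an assay on HEK293 cells for binding affinity to 5-hydroxytryptamine receptor 7 (Homo sapiens), read by radioligand binding, tested at 1 uM (a lower number here means less inhibition, a higher number more inhibition at the concentration tested (going by the name of the read-out)), compound 1 gives 18%, while compound 2 gives 0%. Compound 2 therefore stands at the lowest of the two numbers, and the gap up to compound 1 lies beyond the usual scatter of this assay. Compound 3 `C#Cc1ccc2ccn(CCN3CCCN(C)CC3)c2c1` has not yet been measured. It differs from compound 2 in one place: ethynyl in place of amino on an aromatic carbon. For the measured compounds named here, no pair of measured compounds changes exactly this group, so no measured step tells how large an effect to expect. Compound 1 and compound 2 show only that one substituent on the core gives a modest reading and the amino-bearing compound gives none. For compound 3 a small rise relative to compound 2 is expected, with a number 10 percentage points higher from compound 2 to compound 3 (within the scatter) as the estimated step. Compound 3 is expected to give 10%, in a range from 0% to 30%.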

Compound 3, a percentage reported as inhibition, at one concentration (the size of the read-out at that concentration, not a potency): 79%
Estimate against measurement, compound 3: 69 percentage points below; measured number outside the range, above it.
By their numbers in this assay, from the lowest: compound 2; then compound 1; then compound 3.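

In this assay, putting ethynyl in place of amino on this aromatic carbon gives a number 79 percentage points higher from compound 2 to compound 3 (beyond the scatter), a large step. This shows that a single exchange at this position, meta to a fused ring and para to a fused ring, can decide between no reading and a high one, which compound 1 and compound 2 could not show, since they differ in more than one place. The exchange takes away one hydrogen-bond donor and one acceptor and brings in a triple bond, but nothing available here tells which of these matters.

The compounds shown leave open whether a nitrile, a methyl or a longer alkyne such as propynyl on this carbon would read like ethynyl. They also leave open whether ethynyl would do the same on the carbon that carries bromine in compound 1.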